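The compounds below may be only part of what the source reports. "The series", "measured", "known", "first", "only" and "open" are said of these compounds alone.

Compound 1 `CCOC(=O)C1=C(C)N(c2ccccc2)C=CC1c1ccccc1` is the parent of a small set in which a functional assay for inhibition, using microsomes, tested at 100 ug/mL (a higher number here means a weaker effect of the compound at the concentration tested, a lower number a stronger effect), is the only read-out in hand. In this assay compound 1 gives -19.9%. Two companions change the aryl group on the ring nitrogen: compound 2 `CCOC(=O)C1=C(C)N(c2ccc(F)cc2)C=CC1c1ccccc1` gives -28.5%, and compound 3 `CCOC(=O)C1=C(C)N(c2ccc(Br)cc2)C=CC1c1ccccc1` gives -20.7%. Among these three numbers compound 1 is the highest, but the steps of a number 8.6 percentage points lower from compound 1 to compound 2 (within the scatter) and a number 0.8 percentage points lower from compound 1 to compound 3 (within the scatter) are both within the scatter, as is a number 7.8 percentage points higher from compound 2 to compound 3 (within the scatter), so the three compounds cannot be told apart on this read-out.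

Compound 4 `CCOC(=O)C1=C(C)N(c2ccccc2)C=CC1c1ccccc1[N+](=O)[O-]` differs from compound 1 by nitro in place of hydrogen on an aromatic carbon. Among the compounds with values here, none of the measured steps touches this phenyl ring, and no measured step introduces a nitro group anywhere; what the set does show is that aromatic substitution elsewhere left this assay unchanged within the scatter. On that basis the step of a number 2.1 percentage points lower from compound 1 to compound 4 (within the scatter) is expected to be small, with no direction beyond the scatter. Compound 4 is therefore estimated at -22%, within a range from -42% to -2%.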

Compound 4, a percentage reported as activity, at one concentration (the size of the read-out at that concentration, not a potency): -19.2%
Compound 4: middle estimate off by 2.8 percentage points, on the low side; low and high end bracket the measured number.
By their numbers in this assay, from the lowest: compounds 2, 3, 1 and 4 (each within the scatter of the next).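

Within the data shown here, compound 4 carries the first change on the phenyl ring away from the ring nitrogen: the step from phenyl to 2-nitrophenyl, with the nitro group ortho to a large group, gives a number 0.7 percentage points higher from compound 1 to compound 4 (within the scatter) in this assay. The earlier compounds shown here showed no step beyond the scatter for the aryl group on the ring nitrogen, and this one result adds that nitro at this place on the other ring also leaves compound 4 indistinguishable from compound 1 on this read-out. No measured evidence bears on why this step is so small.

On these data alone, it remains open whether an amine or a carboxylic acid at this same place would give a step beyond the scatter. The compounds shown also leave open whether replacing the ethyl ester with a longer chain would do so.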